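Trifluoromethyl diol amides on HCT-116: trimming the thiazole aryl

The compounds below may be only part of what the source reports. "The series", "measured", "known", "first", "only" and "open" are said of these compounds alone.

Measured in a functional assay on HCT-116 cells (Homo sapiens) for inhibition, read by colorimetric assay, with a stated time of 3 days; on this read-out higher numbers stand for weaker inhibition and lower numbers for stronger inhibition:
compound 1 `CCOc1ccc(-c2cnc(NC(=O)CCCCCCNC(=O)C(O)(O)C(F)(F)F)s2)cc1`: 4050 nM
compound 2 `O=C(CCCCCCNC(=O)C(O)(O)C(F)(F)F)Nc1cccc2ccccc12`: 6480 nM
compound 3 `O=C(CCCCCCNC(=O)C(O)(O)C(F)(F)F)Nc1nc2ccc(Cl)cc2s1`: 11000 nM

Compound 1 gives the lowest number of the three in this assay. Compound 2 sits within the scatter of compound 1, so no order between these two can be read; compound 3 lies beyond the scatter and is the weaker of the pair with compound 1. All three share the seven-carbon chain carrying the trifluoromethyl diol amide and differ only in the aromatic amide part.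

Compound 4 `O=C(CCCCCCNC(=O)C(O)(O)C(F)(F)F)Nc1nccs1` has not been measured in this assay. Against compound 1 the change is:

hydrogen in place of 4-ethoxyphenyl on an aromatic carbon

Among the measured compounds shown here, no measured pair shows this change, so the expectation rests on compound 1 alone. Removing a 9-heavy-atom group from the shared core is expected to weaken inhibition, and a step beyond the scatter is expected, a 2.7-fold higher number from compound 1 to compound 4 (0.43 log units; beyond the scatter). Compound 4 is therefore estimated at 11000 nM in this assay, with a range of 4500 nM to 30000 nM.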

Compound 4, half-maximal inhibitory concentration: 10800 nM
Estimate against measurement, compound 4: 1.0-fold (0.01 log units) above; low and high end bracket the measured number.
By their numbers in this assay, from the lowest: compounds 1, 2, 4 and 3 (each within the scatter of the next, the first and the last beyond it).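

In this assay, among the compounds shown here, hydrogen in place of 4-ethoxyphenyl on the aromatic carbon next to the ring sulfur gives a 2.7-fold higher number from compound 1 to compound 4 (0.43 log units; beyond the scatter), the first single-place comparison. The step ties this position to a difference beyond the scatter, yet the whole group can leave and compound 4 still gives a measured value of 10800 nM, so inhibition in this assay does not depend on the 4-ethoxyphenyl group. No available evidence bears on which feature of the group accounts for the step.

The compounds shown leave open whether the step belongs to the ethoxy part or to the aromatic ring that carries it. A plain phenyl or a 4-methoxyphenyl at this carbon would separate the two.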